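Dropping One Fluoro From a Furan Hydrazide

The source may report more compounds than this note shows. Statements on the series, on what has been measured and on what is new or still open speak of the compounds shown alone.

Measured compounds:
compound 1, `O=C(N/N=C/c1ccccc1)c1ccc(-c2ccc(Cl)cc2)o1`, 17%
compound 2, `O=C(N/N=C/c1ccc(-c2ccc(F)cc2F)o1)c1ccccc1O`, 61.8%

Both numbers come from a functional assay on KB cells (Homo sapiens) for inhibition, read by sulforhodamine B assay, with a stated time of 48 h, tested at 10 uM; on this read-out lower numbers stand for less inhibition of growth and higher numbers for more inhibition of growth at the one concentration tested. Compound 2 stands highest of the two values shown, with compound 1 well below it, a gap beyond the usual scatter; no single change links these two, so their values are only set side by side. Compound 3, `O=C(N/N=C/c1ccc(-c2ccc(F)cc2)o1)c1ccccc1O`, is the next compound and has not yet been measured. It differs from compound 2 in one place: hydrogen in place of fluoro on an aromatic carbon, which, read one bond further out, turns a 2,4-difluorophenyl group into a 4-fluorophenyl group. Among the compounds with values here, with no measured pair of this kind to lean on, the step is expected to be small, at most a slight fall and quite possibly nothing beyond the scatter. For compound 3 the estimated value is 54%, within 35% to 72%, an expected step of a number 7.8 percentage points lower from compound 2 to compound 3 (within the scatter).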

Compound 3, percent growth inhibition at one concentration: 84.6%
Beside the measured number, compound 3's estimate is 30.6 percentage points below it, outside the stated range (above it).
By their numbers in this assay, from the lowest: compound 1; then compound 2; then compound 3.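

In this assay, putting hydrogen in place of the fluoro group that sits ortho to a large group, which turns 2,4-difluorophenyl into 4-fluorophenyl, gives a number 22.8 percentage points higher from compound 2 to compound 3 (beyond the scatter) in this pair. The other fluoro group and the rest of the structure are the same in both compounds, so the step belongs to this one position. At the one concentration tested, this fluoro group is therefore not needed for growth inhibition, and losing it goes with more inhibition, although nothing measured here accounts for the rise.

Going by these compounds, it remains open how this position would respond to a larger group, such as a methoxy group or an amine, in place of the hydrogen. Also open, on these data alone, is whether the remaining fluoro group, meta to the position changed, can be swapped for chloro or hydrogen without a change in growth inhibition.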